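A few compounds are considered here, and "the series" means these few. Any claim that something is new, unique, unknown or untested is made for them only; others in the source may bear on it.

Measured so far:
- compound 1 `CC(C)COc1ccc2c(Cl)ccnc2c1`: 3190 nM
- compound 2 `CCOc1ccc2c(NCCN(C)C)ccnc2c1`: 4620 nM

In a functional assay on SK-OV-3 cells (Homo sapiens) for cytotoxicity, read by MTT assay, with a stated time of 48 h (a lower number here means a stronger inhibitor, a higher number a weaker inhibitor), compound 1 gives 3190 nM and compound 2 gives 4620 nM; compound 1 holds the lower of the two numbers, but the gap lies within the scatter, so no order is read from it.

Compound 3 `C=CCOc1ccc2c(Cl)ccnc2c1` is not yet measured. It differs from compound 1 by vinyl in place of isopropyl on a saturated chain carbon bound to an oxygen on an aromatic ring. Within the data shown here, no step between measured compounds covers such a change, so nothing from the pair above bears on it. For compound 3 the step of a 1.1-fold higher number from compound 1 to compound 3 (0.04 log units; within the scatter) is expected to stay within the scatter, in no set direction. In this assay compound 3 is expected to give about 3500 nM, between 1500 nM and 8000 nM.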

Compound 3, half-maximal inhibitory concentration: 4030 nM
Beside the measured number, compound 3's estimate is 1.2-fold (0.06 log units) below it; the measured number falls inside the stated range.
By their numbers in this assay, from the lowest: compounds 1, 3 and 2 (each within the scatter of the next).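

In this assay the change from isobutoxy to allyloxy gives a 1.3-fold higher number from compound 1 to compound 3 (0.10 log units; within the scatter) and so stays within the scatter. Among these compounds, this is the first step read at this place, on a saturated chain carbon bound to an oxygen on an aromatic ring, and vinyl in place of isopropyl does not separate the two compounds. No measurement at hand offers an explanation for this result. Still open, from the compounds shown here alone, is whether a longer chain, a phenyl ring or an amine at this place would give a step beyond the scatter.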